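Chloro in Place of Fluoro on the Aryl Ring

This account rests on a few compounds, and the source may have more. Where it says the series, first, only, none or still open, it means among the compounds named here.

Three compounds share one core and differ only in the aryl group on the carbon that carries a double bond to nitrogen. Compound 1 `COc1ccc2cc(C(C)c3nnc4n3N=C(c3ccc(Cl)cc3Cl)CS4)ccc2c1` bears a 2,4-dichlorophenyl there, and in a functional assay on HCT-116 cells (Homo sapiens) for inhibition, read by sulforhodamine B assay, with a stated time of 72 h (a lower number here means a stronger inhibitor, a higher number a weaker inhibitor), compound 1 gives 14000 nM. Compound 2 `COc1ccc2cc(C(C)c3nnc4n3N=C(c3ccc(F)cc3)CS4)ccc2c1` bears a 4-fluorophenyl, and in this assay compound 2 gives 13100 nM, the lower of the two numbers at hand, although the step of a 1.1-fold lower number from compound 1 to compound 2 (0.03 log units; within the scatter) leaves the two values within the scatter of each other. Compound 3 `COc1ccc2cc(C(C)c3nnc4n3N=C(c3ccc(Cl)cc3)CS4)ccc2c1` has not been measured; it differs from compound 2 by chloro in place of fluoro on an aromatic carbon. Within the data shown here, the one measured step that bears on this change is a 1.1-fold lower number from compound 1 to compound 2 (0.03 log units; within the scatter), which swapped one halogenated phenyl for another and moved the number hardly at all. The change to compound 3 is a smaller one than that, so no shift beyond the scatter is expected in this assay. Compound 3 is therefore estimated at 13000 nM, with a range from 5500 nM to 30000 nM. The expected step is a 1.0-fold lower number from compound 2 to compound 3 (0.00 log units; within the scatter).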

Compound 3, half-maximal inhibitory concentration: 8800 nM
Estimate against measurement, compound 3: 1.5-fold (0.17 log units) above, within the range that was stated.
By their numbers in this assay, from the lowest: compounds 3, 2 and 1 (each within the scatter of the next).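

In this assay, chloro in place of fluoro on an aromatic carbon, para to a large group, gives a 1.5-fold lower number from compound 2 to compound 3 (0.17 log units; within the scatter), and hydrogen in place of chloro on an aromatic carbon gives a 1.6-fold lower number from compound 1 to compound 3 (0.20 log units; within the scatter). With three aryl groups now measured at this position, every pair of values lies within the scatter, so neither the identity of the halogen at the position para to the large group nor the presence of the second chloro group separates these compounds in this assay. No independent evidence accompanies these numbers, and they offer no account of why the steps are so small.

Going by these compounds, all three compounds carry only halogens on this phenyl ring, so it remains open whether an amine, a carboxylic acid or a methoxy group there would shift the number beyond the scatter. The compounds shown also share the rest of the core unchanged, which leaves open how a longer chain in place of its methyl group, or a hydroxy group in place of its methoxy group, would read in this assay.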